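The source may hold more compounds than are shown below. What is called first, only, known or untested is meant among the compounds shown, and "the series" means these compounds.

Series built on the shared core, with variation only on the amine nitrogen in a ring. Compound 1 `Nc1ccccc1NC(=O)c1ccc(CSC(=S)N2CCN(c3ncccn3)CC2)cc1` gives 24% in a functional assay on A-375 cells (Homo sapiens) for antiproliferative activity, read by CCK-8 assay, with a stated time of 72 h, tested at 2 uM; on this read-out lower numbers stand for a weaker effect and higher numbers for a stronger effect at the one concentration tested; compound 2 `Nc1ccccc1NC(=O)c1ccc(CSC(=S)N2CCN(Cc3cccnc3)CC2)cc1` gives 31.5%; compound 3 `Nc1ccccc1NC(=O)c1ccc(CSC(=S)N2CCN(c3ccccc3F)CC2)cc1` gives 18.7%. Compound 3 is reached by a number 5.3 percentage points lower from compound 1 to compound 3 (within the scatter) and by a number 12.8 percentage points lower from compound 2 to compound 3 (beyond the scatter), so only the move from compound 2 sets it apart. Compound 4 `Nc1ccccc1NC(=O)c1ccc(CSC(=S)N2CCN(c3ccncc3)CC2)cc1` carries pyridin-4-yl in place of 2-fluorophenyl on an amine nitrogen in a ring. Among the measured compounds shown here, the steps that bear on this exchange of one aromatic group for another on the same nitrogen are a number 5.3 percentage points lower from compound 1 to compound 3 (within the scatter) and a number 7.5 percentage points higher from compound 1 to compound 2 (within the scatter), both small, and a number 12.8 percentage points lower from compound 2 to compound 3 (beyond the scatter), modest. A step of a number 3.3 percentage points higher from compound 3 to compound 4 (within the scatter) is therefore expected, upward but not clearly beyond the scatter. Compound 4 is estimated at 22%, within 10% to 35%.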

Compound 4, a percentage reported as inhibition, at one concentration (the size of the read-out at that concentration, not a potency): 85.7%
For compound 4 the middle estimate is 63.7 percentage points below the measured one, outside the stated range (above it).
By their numbers in this assay, from the lowest: compounds 3, 1 and 2 (each within the scatter of the next, the first and the last beyond it); then compound 4.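

In this assay the group on this nitrogen can move the read-out far more than the earlier small or modest steps showed, with pyridin-4-yl giving a number 67 percentage points higher from compound 3 to compound 4 (beyond the scatter) and a number 54.2 percentage points higher from compound 2 to compound 4 (beyond the scatter) and a number 61.7 percentage points higher from compound 1 to compound 4 (beyond the scatter) as large steps. A hetero atom in the aromatic ring is not enough on its own, as compound 1 and compound 2 also carry ring nitrogen yet stay far from compound 4. No measurement here accounts for the jump.

Going by these compounds, whether directly attached pyridin-3-yl, pyridin-2-yl or unsubstituted phenyl reaches the level of compound 4 remains open.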